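The source may report more compounds than this note shows. Statements on the series, on what has been measured and on what is new or still open speak of the compounds shown alone.

Going by the values given here, in a functional assay (aorta) with Oryctolagus cuniculus as the target (a higher number here means a weaker inhibitor, a lower number a stronger inhibitor), compound 3 `CCc1cnc(-c2nn(Cc3ccccc3F)c3ncccc23)nc1N` gives 272000 nM, the highest of the three numbers measured so far. Compound 1 `OCc1ccc(-c2nn(Cc3cncnc3)c3ccccc23)o1` gives 3200 nM in this assay, and compound 2 `Cc1nc(-c2nn(Cc3ccccc3F)c3ncccc23)oc1CO` gives 900 nM; the gap from each of them to compound 3 lies beyond the scatter, compound 2 being the furthest away. Compound 4 `Nc1nc(-c2nn(Cc3ccccc3F)c3ncccc23)ncc1C1CCCCC1` has not yet been measured in this assay. It differs from compound 3 in a single place: cyclohexyl in place of ethyl on an aromatic carbon. Among the compounds with values here, no pair of measured compounds shows a step of this kind, so nothing in the data sets its size. A small step toward a lower number is expected, one that may well stay within the scatter, a 1.8-fold lower number from compound 3 to compound 4 (0.26 log units; within the scatter). Compound 4 is therefore estimated at 150000 nM in this assay, with a range from 30000 nM to 600000 nM.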

Compound 4, half-maximal inhibitory concentration: 561000 nM
Compound 4: middle estimate off by 3.7-fold (0.57 log units), on the low side; low and high end bracket the measured number.
By their numbers in this assay, from the lowest: compound 2; then compound 1; then compound 3; then compound 4.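

In this assay, cyclohexyl in place of ethyl on this aromatic carbon, ortho to an amino group, gives a 2.1-fold higher number from compound 3 to compound 4 (0.31 log units; beyond the scatter). Going by these compounds alone, this modest step shows that the six-membered carbon ring does not bring the number down at this position, where compound 3 already stood highest among the earlier compounds. Nothing measured here accounts for the rise. The compounds shown leave open how a hydroxymethyl group or a carboxylic acid on this carbon would compare with ethyl and cyclohexyl. They also leave open whether a phenyl ring would behave like cyclohexyl.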